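Trimming a methoxy on the carbonyl-side aryl

This account rests on a few compounds, and the source may have more. Where it says the series, first, only, none or still open, it means among the compounds named here.

Three chalcone-like compounds sharing a core were measured in a functional assay on T47D cells (Homo sapiens) for cytotoxicity, read by sulforhodamine B assay, with a stated time of 48 h, tested at 10 uM; on this read-out higher numbers stand for a weaker effect at the one concentration tested and lower numbers for a stronger effect. Compound 1 `COc1cc(-c2cc(/C=C/C(=O)c3ccc(N)cc3)[nH]n2)cc(OC)c1OC` gives -38%, compound 2 `COc1cc(-c2cc(/C=C/C(=O)c3ccc(Cl)c(Cl)c3)[nH]n2)cc(OC)c1OC` gives 9%, and compound 3 `COc1ccc(C(=O)/C=C/c2cc(-c3cc(OC)c(OC)c(OC)c3)n[nH]2)cc1OC` gives -42%, the lowest number of the three, though compound 1 lies within the scatter of it. Compound 4 `COc1ccc(C(=O)/C=C/c2cc(-c3cc(OC)c(OC)c(OC)c3)n[nH]2)cc1` differs from compound 3 by hydrogen in place of methoxy on an aromatic carbon. Among the measured compounds shown here, the steps that bear on this swap both change the aryl on the carbonyl carbon: a number 4 percentage points lower from compound 1 to compound 3 (within the scatter) and a number 51 percentage points lower from compound 2 to compound 3 (beyond the scatter). Compound 4 keeps a methoxy-bearing aryl, so the author expects a step of a number 12 percentage points higher from compound 3 to compound 4 (beyond the scatter) in this assay, small and likely within the scatter. Compound 4 is estimated at -30%, between -60% and 5%.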

Compound 4, a percentage reported as activity, at one concentration (the size of the read-out at that concentration, not a potency): 1%
The estimate for compound 4 lay 31 percentage points below the measured number; the measured number falls inside the stated range.
By their numbers in this assay, from the lowest: compounds 3 and 1 (each within the scatter of the next); then compounds 4 and 2 (each within the scatter of the next).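

In this assay, this one methoxy, ortho to the remaining methoxy group, matters: going from 3,4-dimethoxyphenyl to 4-methoxyphenyl gives a number 43 percentage points higher from compound 3 to compound 4 (beyond the scatter), so merely keeping a methoxy-bearing aryl does not preserve the stronger effect. The new aryl also gives a number 8 percentage points lower from compound 2 to compound 4 (within the scatter), while methoxy in place of amino gives a number 39 percentage points higher from compound 1 to compound 4 (beyond the scatter), so the lone methoxy does not match the amino group here. Nothing available explains the step. On these data alone, it remains open whether a hydroxyl, fluorine or amine at this place would restore the stronger effect.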